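The source may report more compounds than this note shows. Statements on the series, on what has been measured and on what is new or still open speak of the compounds shown alone.

Three closely related compounds have been measured in an assay on RBL-1 cells with Polyunsaturated fatty acid 5-lipoxygenase (Rattus norvegicus) as the target; on this read-out lower numbers stand for stronger inhibition and higher numbers for weaker inhibition. Compound 1 `Cc1ccc(Cc2ccc3ccccc3c2O)cc1` gives 24 nM in this assay. Compound 2 `Cc1ccc(C)c2c(O)c(Cc3ccccc3)ccc12` gives 120 nM in this assay. Compound 3 `Cc1cc(Cc2ccccc2)c(O)c2ccccc12` gives 20 nM in this assay. Among these three numbers compound 3 has the lowest, but its gap to compound 1 lies within the usual scatter, so those two cannot be told apart; only compound 2 stands apart, beyond the scatter from compound 3.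

Compound 4 `CC(=O)c1cc(Cc2ccccc2)c(O)c2ccccc12` has not been measured yet. It differs from compound 3 in one place: acetyl in place of methyl on an aromatic carbon. Among the measured compounds shown here, no measured pair shows this particular change, so there is no directly comparable step to lean on. What the three measured compounds do show is that a single alteration on the shared core can move the number beyond the scatter, as compound 2 does against compound 3, or stay within it, as compound 1 does. Swapping the methyl for an acetyl is a different kind of change from either of those, and the expectation here is a modest loss rather than none. For compound 4 the expected step is a 3.0-fold higher number from compound 3 to compound 4 (0.48 log units; beyond the scatter). Compound 4 is estimated at 60 nM in this assay, with a plausible range from 15 nM to 250 nM.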

Compound 4, half-maximal inhibitory concentration: 510 nM
Beside the measured number, compound 4's estimate is 8.5-fold (0.93 log units) below it; measured number above the stated range.
By their numbers in this assay, from the lowest: compounds 3 and 1 (each within the scatter of the next); then compound 2; then compound 4.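

In this assay, the aromatic carbon para to a hydroxy group proves sensitive to what it carries: acetyl in place of methyl gives a 26-fold higher number from compound 3 to compound 4 (1.41 log units; beyond the scatter) and so a large loss of inhibition. Among the compounds shown here, this is the first step in the set that isolates a change at this carbon, since no earlier pair differed in one place only. Nothing available here explains why the number rises so far.

The pair of compound 3 and compound 4 cannot separate the possible contributions of the extra heavy atoms of the acetyl from those of its carbonyl, which brings a hydrogen-bond acceptor that the methyl lacks. As far as these compounds go, how this carbon would respond to an ethyl chain, which adds carbon without a carbonyl, or to an amine or a carboxylic acid remains open, so a single step cannot show whether the loss is specific to acetyl or extends to other replacements for the methyl.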